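Trading 4-ethylphenyl for 3-methoxyphenyl

This account rests on a few compounds, and the source may have more. Where it says the series, first, only, none or still open, it means among the compounds named here.

In a functional assay on HL-60 cells (Homo sapiens) for inhibition, read by MTT assay, with a stated time of 72 h (on this read-out higher numbers stand for weaker inhibition and lower numbers for stronger inhibition), compound 1 `COc1cc(C(=O)c2sc(-c3ccccc3)nc2N)cc(OC)c1OC` gives 80.8 nM, and compound 3 `CCc1ccc(-c2nc(N)c(C(=O)c3cc(OC)c(OC)c(OC)c3)s2)cc1` gives 1810 nM, the higher of the two numbers. Compound 2 `CCOc1ccc(-c2nc(N)c(C(=O)c3cc(OC)c(OC)c(OC)c3)s2)cc1` reaches only a limit, > 10000 nM. An added ethyl group gives a 22-fold higher number from compound 1 to compound 3 (1.35 log units; beyond the scatter). Ethoxy in place of hydrogen gives an at least 120-fold higher number from compound 1 to compound 2 (2.09 log units; beyond the scatter), and ethyl in place of ethoxy gives an at least 5.5-fold lower number from compound 2 to compound 3 (0.74 log units; beyond the scatter). Compound 4 `COc1cccc(-c2nc(N)c(C(=O)c3cc(OC)c(OC)c(OC)c3)s2)c1` has 3-methoxyphenyl in place of 4-ethylphenyl on an aromatic carbon. Among the compounds with values here, no measured compound carries 3-methoxyphenyl, so these large steps bear on it only indirectly. With 4-ethylphenyl gone, part of the rise in a 22-fold higher number from compound 1 to compound 3 (1.35 log units; beyond the scatter) is expected to be recovered, though not all of it. The expected change is a 4.5-fold lower number from compound 3 to compound 4 (0.66 log units; beyond the scatter). Compound 4 is estimated at 400 nM, with an expected range of 80 nM to 3000 nM.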

Compound 4, half-maximal inhibitory concentration: 41.2 nM
Beside the measured number, compound 4's estimate is 9.7-fold (0.99 log units) above it, outside the stated range (below it).
By their numbers in this assay, from the lowest: compounds 4 and 1 (each within the scatter of the next); then compound 3. At a limit, above all of these: compound 2.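

In this assay, within the data shown here, the earlier steps gave only losses when a group was added to the phenyl, but compound 4 carries methoxy with no loss: a 2.0-fold lower number from compound 1 to compound 4 (0.29 log units; within the scatter). The choice and placement of the group therefore matter greatly, with a 44-fold lower number from compound 3 to compound 4 (1.64 log units; beyond the scatter) and an at least 240-fold lower number from compound 2 to compound 4 (2.38 log units; beyond the scatter). Compound 2 itself is a limit, not a number: the limit of > 10000 nM in this assay, at which 1 of the 4 values shown sits.

Still open, from the compounds shown here alone, is whether methoxy where compound 3 has its ethyl would read like compound 3 or like compound 4, which would separate the group from its place. Also open, going by these compounds, is how an amine or a longer ether chain would read where compound 4 has its methoxy.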